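Thioether substituent exchange: next member of the series

The source may hold more compounds than are shown below. What is called first, only, known or untested is meant among the compounds shown, and "the series" means these compounds.

Among the compounds with values here, compound 2 `Nc1ccccc1NC(=O)/C=C/c1ccc(CSc2ccc(C(F)(F)F)cn2)cc1` holds the lowest of the two numbers measured so far in a functional assay on A549 cells (Homo sapiens) for inhibition, read by CCK-8 assay, with a stated time of 72 h, tested at 8 uM; a higher number here means more inhibition of growth at the concentration tested, a lower number less inhibition of growth. Compound 2 gives 56.5%, while compound 1 `Nc1ccccc1NC(=O)/C=C/c1ccc(CSc2cccc3ccccc23)cc1` gives 71.2%. Within the data shown here, the only measured step, a number 14.7 percentage points lower from compound 1 to compound 2 (beyond the scatter), is the sole reference for what an exchange of the group on the sulfur does to the growth read-out.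

Compound 3 `Nc1ccccc1NC(=O)/C=C/c1ccc(CSCCc2ccccc2)cc1` is the next member to be measured. It differs from compound 2 as follows: phenethyl in place of 5-(trifluoromethyl)pyridin-2-yl on a sulfur. The step from compound 1 to compound 2 bears on this change only loosely, because a number 14.7 percentage points lower from compound 1 to compound 2 (beyond the scatter) shows that exchanging one aromatic group on the sulfur for another moved the read-out by a modest amount. Among the measured compounds shown here, whether phenethyl on the sulfur behaves like either of the two aromatic groups is not known; no measured step covers such a group. The expectation is therefore a step of uncertain direction and modest size, a number 5.5 percentage points higher from compound 2 to compound 3 (within the scatter), so that compound 3 is estimated at 62% in this assay, with a range from 46% to 78%.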

Compound 3, percent growth inhibition at one concentration: 50.3%
For compound 3 the middle estimate is 11.7 percentage points above the measured one; the measured number falls inside the stated range.
By their numbers in this assay, from the lowest: compounds 3 and 2 (each within the scatter of the next); then compound 1.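

Read at the sulfur, this assay now covers a group joined through a saturated chain carbon, and the step of a number 6.2 percentage points lower from compound 2 to compound 3 (within the scatter) leaves phenethyl and 5-(trifluoromethyl)pyridin-2-yl indistinguishable, although the entering group has one six-membered aromatic ring of carbon only and no hetero atom or fluorine. The step of a number 20.9 percentage points lower from compound 1 to compound 3 (beyond the scatter) adds a second comparison against naphthalen-1-yl, so that compound 1 now stands apart from both other members of the series, while compound 2 and compound 3 form one level within the scatter. Among these three compounds, the exchange of the group on the sulfur thus separates naphthalen-1-yl from the other two groups, but no measurement at hand offers an explanation for that separation.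

On these data alone, it remains open whether naphthalen-2-yl or a plain phenyl on the sulfur would stay at the level of compound 1 or fall to that of compound 2 and compound 3. A longer chain ending in phenyl, or a chain carrying an amine or a carboxylic acid, would show how far the group on the sulfur can be varied in this growth read-out.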